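The source may hold more compounds than are shown below. What is called first, only, known or untested is meant among the compounds shown, and "the series" means these compounds.

Compound 3 `CCOC(=O)c1cc(-c2cccc(OCc3ccccc3Cl)c2)on1` stands only at a limit in an ADME assay on Vero cells (Chlorocebus sabaeus) for cytotoxicity, with a stated time of 72 h (a lower number here means a stronger inhibitor, a higher number a weaker inhibitor), where compound 3 gives > 128000 nM. Compound 1 `CCOC(=O)c1cc(-c2cccc(OCc3cccc([N+](=O)[O-])c3)c2)on1` likewise reaches only a limit, and in this assay compound 1 gives > 128000 nM. Compound 2 `CCOC(=O)c1cc(-c2cccc(OCc3cccc(N)c3)c2)on1` also gives only a limit, which in this assay is > 128000 nM. The step that the two limits leave unreadable from compound 1 to compound 2 is thus unreadable, as are the steps at the same place as the present change, a step that the two limits leave unreadable from compound 1 to compound 3 and a step that the two limits leave unreadable from compound 2 to compound 3, since the limit of > 128000 nM in this assay, at which 3 of the 3 values shown sit, holds all three values.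

Compound 4 `CCOC(=O)c1cc(-c2cccc(OCc3ccc(F)c(F)c3)c2)on1` differs from compound 3 in one place: 3,4-difluorophenyl in place of 2-chlorophenyl on a saturated chain carbon bound to an oxygen on an aromatic ring. Going by the values given here, no measured step at this place yields a readable size, and none of the three compounds leaves the limit. Compound 4 is therefore expected to remain at the limit of this assay, the estimated step that the limit leaves unreadable from compound 3 to compound 4 being no change beyond the scatter. The estimate for compound 4 is 150000 nM, with a range from 64000 nM to 400000 nM.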

Compound 4, half-maximal inhibitory concentration: > 128000 nM
Compound 4: no number, only a limit; the forecaster's own chance of this, stated with the estimate: 85%; the middle value lies beyond the limit too.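

In this assay compound 4 gives > 128000 nM, a limit and not a number, so its steps from compound 1, compound 2 and compound 3 cannot be read: the limit of > 128000 nM in this assay, at which 4 of the 4 values shown sit.

The compounds shown leave open whether any group at this place changes the half-maximal inhibitory concentration at all.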